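Thiosemicarbazones on RD cells: compound 2 towards compound 4

The source may hold more compounds than are shown below. What is called first, only, known or untested is meant among the compounds shown, and "the series" means these compounds.

Measured so far:
compound 1, `O=C1Nc2ccc(OC(F)(F)F)cc2/C1=N/NC(=S)Nc1ccccc1`: > 25000 nM
compound 2, `O=C1Nc2ccccc2/C1=N/NC(=S)Nc1ccc(Cl)cc1`: > 25000 nM
compound 3, `CCCN(CCC)C(=S)N/N=C1/C(=O)Nc2ccccc21`: > 25000 nM

In an ADME assay on RD cells (Homo sapiens) for cytotoxicity (a lower number here means that less compound is tolerated, a higher number that more compound is tolerated), compound 1 gives > 25000 nM, which is a limit of the assay and not a number. Compound 2 gives > 25000 nM in this assay, again only a limit. Compound 3 gives > 25000 nM in this assay, also a limit. Compound 2 therefore stands exactly where the rest of the set stands: the limit of > 25000 nM in this assay, at which 3 of the 3 values shown sit. Going by the values given here, no pair of measured compounds differs in only one place, so no measured step exists and no compound can be ranked against another.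

Compound 4, `CCNC(=S)N/N=C1\C(=O)Nc2ccccc21`, has not been measured. It differs from compound 2 in one place: ethyl in place of 4-chlorophenyl on an amide-type nitrogen. Compound 3 carries two propyl chains on the same kind of nitrogen and still sits at the limit with > 25000 nM, so the move from an aryl to a small alkyl substituent there is expected to bring no step beyond the scatter in this assay. The expected change from compound 2 to compound 4 is a step that the limit leaves unreadable from compound 2 to compound 4, essentially flat. Compound 4 is expected at 30000 nM, within 12000 nM to 80000 nM, most likely reported once more as a limit only.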

Compound 4, half-maximal cytotoxic concentration: > 25000 nM
Compound 4 ended at the assay's limit (the forecaster's own chance of this, stated with the estimate: 85%); the middle value is on the limit's open side.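

In this assay compound 4 gives > 25000 nM as a limit of the assay and not a number. Compound 2 also sits at a limit, so no step can be read for ethyl in place of 4-chlorophenyl, and the set stays in one place: the limit of > 25000 nM in this assay, at which 4 of the 4 values shown sit. The compounds shown leave open which change, if any, would bring a measurable value in this assay.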